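The source may report more compounds than this note shows. Statements on the series, on what has been measured and on what is new or still open speak of the compounds shown alone.

Compound 1 `Nc1cccc(Nc2nc3ccccc3nc2S(=O)(=O)c2ccccc2)c1`: 1590 nM
Compound 2 `Nc1ccc(Nc2nc3ccccc3nc2S(=O)(=O)c2ccc(Br)cc2)cc1`: 1020 nM

In a functional assay on A549 cells (Homo sapiens) for cytotoxicity, read by MTT assay, with a stated time of 72 h (a lower number here means a stronger inhibitor, a higher number a weaker inhibitor), compound 2 gives 1020 nM and compound 1 gives 1590 nM, two numbers within the usual scatter of each other. Compound 3 `Nc1cccc(Nc2nc3ccccc3nc2S(=O)(=O)c2ccc(Br)cc2)c1` has 3-aminophenyl in place of 4-aminophenyl on a nitrogen on an aromatic ring. Among the measured compounds shown here, no measured pair shows this change alone, so the data offer no direct guide to its size. The estimated step of a 1.2-fold higher number from compound 2 to compound 3 (0.07 log units; within the scatter) is expected to stay within the scatter in this assay, with no clear direction. Compound 3 is estimated at 1200 nM, with an expected range of 450 nM to 3200 nM.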

Compound 3, half-maximal inhibitory concentration: 1120 nM
The estimate for compound 3 lay 1.1-fold (0.03 log units) above the measured number; the measured number falls inside the stated range.
By their numbers in this assay, from the lowest: compounds 2, 3 and 1 (each within the scatter of the next).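

In this assay the exchange of 4-aminophenyl for 3-aminophenyl on a nitrogen on an aromatic ring gives a 1.1-fold higher number from compound 2 to compound 3 (0.04 log units; within the scatter) and so does not separate the two compounds. Bromo in place of hydrogen on an aromatic carbon gives a 1.4-fold lower number from compound 1 to compound 3 (0.15 log units; within the scatter) and likewise stays within the scatter, so neither change has a measurable effect in these compounds. No measurement here offers an explanation for these results.

Going by these compounds, whether a hydroxyl or carboxylic acid in place of the amine would give a step beyond the scatter stays open. The same holds for chloro or methoxy in place of bromo.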